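Methylcarbamoyl in place of the pyrazolyl on the shared core

A few compounds are considered here, and "the series" means these few. Any claim that something is new, unique, unknown or untested is made for them only; others in the source may bear on it.

Compound 1 `Cc1n[nH]cc1-c1cccc2c1CCC2c1ncc[nH]1` holds the top of the three measured numbers in a functional assay on CHO cells for agonist activity at Alpha-1A adrenergic receptor (Homo sapiens), read by FLIPR and calcium flux (a higher number here means a larger maximal response, a lower number a smaller maximal response), and gives 91%. Compound 2 `c1ccc(-c2cccc3c2CCC3c2ncc[nH]2)nc1` gives 53% and compound 3 `Cc1oncc1-c1cccc2c1CCC2c1ncc[nH]1` gives 63%. Both steps away from compound 1 lower the maximal response: a number 38 percentage points lower from compound 1 to compound 2 (beyond the scatter) and a number 28 percentage points lower from compound 1 to compound 3 (beyond the scatter); the step of a number 10 percentage points higher from compound 2 to compound 3 (within the scatter) stays within the scatter. Compound 4 `CNC(=O)c1cccc2c1CCC2c1ncc[nH]1` differs from compound 1 by methylcarbamoyl in place of 3-methyl-1H-pyrazol-4-yl on an aromatic carbon. For the measured compounds named here, the steps of a number 38 percentage points lower from compound 1 to compound 2 (beyond the scatter) and a number 28 percentage points lower from compound 1 to compound 3 (beyond the scatter) each replaced this same group and each fell beyond the scatter; the entering group has no ring, so no measured step matches it closely. For compound 4 a fall of comparable size is therefore expected in this assay, namely a number 36 percentage points lower from compound 1 to compound 4 (beyond the scatter). Compound 4 is estimated at 55%, within 30% to 85%.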

Compound 4, largest response reached (Emax), in percent of the reference or control that the assay uses: 59%
The estimate for compound 4 lay 4 percentage points below the measured number, and the stated range covers the measured number.
By their numbers in this assay, from the lowest: compounds 2, 4 and 3 (each within the scatter of the next); then compound 1.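

At this aromatic carbon the ring-free methylcarbamoyl gives the same picture in this assay as the two ring replacements: a number 32 percentage points lower from compound 1 to compound 4 (beyond the scatter) and the result sits level with both, with a number 4 percentage points lower from compound 3 to compound 4 (within the scatter) and a number 6 percentage points higher from compound 2 to compound 4 (within the scatter). Among these four compounds, only compound 1 with its 3-methyl-1H-pyrazol-4-yl stands apart, and a ring at this place is not required to match compounds 2 and 3. Nothing available explains why compound 1 stands apart.

Still open, from the compounds shown here alone, is whether an unmethylated 1H-pyrazol-4-yl keeps the response of compound 1. Also open, going by these compounds, is whether a carboxylic acid or a primary amine at this carbon stays level with compounds 2, 3 and 4.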